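This account rests on a few compounds, and the source may have more. Where it says the series, first, only, none or still open, it means among the compounds named here.

Of the compounds shown here, three sharing one core have been measured in an assay on HEK293 cells for displacement of a labelled ligand from 5-hydroxytryptamine receptor 6 (Homo sapiens); on this read-out lower numbers stand for stronger inhibition and higher numbers for weaker inhibition. Compound 1 `COc1ccccc1N1CCN(CCCCCN2C(=O)c3ccccc3S2(=O)=O)CC1` gives 1990 nM. Compound 2 `O=C1c2ccccc2S(=O)(=O)N1CCCCCCN1CCN(c2ccc(Cl)cc2)CC1` gives 72 nM, and compound 3 `O=C1c2ccccc2S(=O)(=O)N1CCCCN1CCN(c2cccc(Cl)c2Cl)CC1` gives 2660 nM. Compound 1 thus stands second highest of the three numbers: its gap to compound 3 lies within the scatter, while compound 2 sits far beyond it, at a much lower number. Compound 4 `O=C1c2ccccc2S(=O)(=O)N1CCCCCN1CCN(c2cccc3ccccc23)CC1` has not yet been measured in this assay. It differs from compound 1 in one place: naphthalen-1-yl in place of 2-methoxyphenyl on an amine nitrogen in a ring. Among the measured compounds shown here, no measured pair shows this exchange, so its effect is not known from these data. The expectation for compound 4 is nevertheless a lower number, with the step of a 6.6-fold lower number from compound 1 to compound 4 (0.82 log units; beyond the scatter) expected to reach beyond the scatter. Compound 4 is estimated at 300 nM, between 60 nM and 1500 nM.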

Compound 4, inhibition constant: 101 nM
Compound 4: middle estimate off by 3.0-fold (0.47 log units), on the high side, within the range that was stated.
By their numbers in this assay, from the lowest: compounds 2 and 4 (each within the scatter of the next); then compounds 1 and 3 (each within the scatter of the next).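

Replacing 2-methoxyphenyl with naphthalen-1-yl on the amine nitrogen, while the chain and the shared core stay the same, gives a 20-fold lower number from compound 1 to compound 4 (1.29 log units; beyond the scatter) and so shows that this position responds strongly to the group it carries. Among the compounds shown here, this is the first exchange here that can be read in a pair differing in one place. Nothing available explains why the number falls.

Still open, as far as these compounds go, is whether the gain follows from the second aromatic ring or from the loss of the methoxy group. Plain phenyl or naphthalen-2-yl at this position would help to separate these two readings.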